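The source may hold more compounds than are shown below. What is called first, only, known or untested is meant among the compounds shown, and "the series" means these compounds.

Working notes on the series. Compound 1 `S=C(Nc1ccc(Cl)cc1)Nc1nc2ccccc2s1` gives no number in a functional assay on U-937 cells (Homo sapiens) for cytotoxicity, read by MTT assay, with a stated time of 48 h (on this read-out lower numbers stand for stronger inhibition and higher numbers for weaker inhibition), but only the limit > 50000 nM; this is the limit of > 50000 nM in this assay, at which 1 of the 3 values shown sits. Compound 3 `Fc1ccc(NC(=S)Nc2nc3ccccc3s2)cc1` gives 32100 nM in this assay. Within the data shown here, the step of an at least 1.5-fold lower number from compound 1 to compound 3 (0.19 log units; that floor lies within the scatter) is the only measured step, and it changes the ring that carries the chloro, not the fused ring. Among the measured compounds shown here, compound 2 `CCOc1ccc2nc(Nc3nc4ccc(F)cc4s3)sc2c1`, built differently, gives 26600 nM in this assay; no step to it is computed, so its value is noted and nothing more. Compound 4 `Fc1ccc2nc(NC(=S)Nc3ccc(Cl)cc3)sc2c1` differs from compound 1 by fluoro in place of hydrogen on an aromatic carbon. For the measured compounds named here, no measured step alters the fused ring of the shared core of compound 1, so this change has no direct precedent. Because compound 1 stands at > 50000 nM, the size of any step from it is uncertain in both directions. The step of an at least 1.5-fold lower number from compound 1 to compound 3 (0.19 log units; that floor lies within the scatter) shows a halogen exchange leaving compound 3 weak, so no step beyond the scatter is expected in this assay. Compound 4 is expected at 40000 nM, between 20000 nM and 100000 nM. The expected step is an at least 1.2-fold lower number from compound 1 to compound 4 (0.09 log units; that floor lies within the scatter).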

Compound 4, half-maximal inhibitory concentration: 18700 nM
For compound 4 the middle estimate is 2.1-fold (0.33 log units) above the measured one; measured number outside the range, below it.
By their numbers in this assay, from the lowest: compounds 4, 2 and 3 (each within the scatter of the next). At a limit, above all of these: compound 1.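

Fluoro in place of hydrogen on an aromatic carbon of the fused system, meta to a fused ring and para to a fused ring, gives in this assay an at least 2.6-fold lower number from compound 1 to compound 4 (0.42 log units; beyond the scatter), the only step shown that lies beyond the scatter. This position on the shared core, untouched by the earlier step, therefore responds to a single fluoro, whereas the halogen exchange on the other ring gave only a floor within the scatter. Compound 1 stands at a limit, so this step is a floor and its true size stays unknown: the limit of > 50000 nM in this assay, at which 1 of the 4 values shown sits.

From the compounds shown here alone, whether an amine or a methoxy group at this same position would give a step like that of fluoro stays open. Also open, going by these compounds, is whether the same fluoro gives a comparable step on compound 3.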